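The source may report more compounds than this note shows. Statements on the series, on what has been measured and on what is new or still open speak of the compounds shown alone.

Compound 1 `O=C1/C(=C\c2ccccc2)c2c(ncn2COCc2ccccc2)CCN1Cc1ccccc1`: 20000 nM
Compound 2 `Cc1cccc(CN2CCc3ncn(COCc4ccccc4)c3/C(=C/c3ccccc3)C2=O)c1`: 3800 nM

In a functional assay on HCT-116 cells (Homo sapiens) for inhibition, read by MTT assay, with a stated time of 72 h (on this read-out higher numbers stand for weaker inhibition and lower numbers for stronger inhibition), compound 2 gives 3800 nM, the lowest of the two numbers measured, and compound 1 gives 20000 nM. For the measured compounds named here, the single measured step, a 5.3-fold lower number from compound 1 to compound 2 (0.72 log units; beyond the scatter), shows that a methyl in place of hydrogen on an aromatic carbon of the benzyl group lowered the number beyond the scatter.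

Compound 3 `CC(C)(C)c1ccc(CN2CCc3ncn(COCc4ccccc4)c3/C(=C/c3ccccc3)C2=O)cc1` carries a different substituent on that same benzyl group: 4-(tert-butyl)phenyl in place of 3-methylphenyl on a saturated chain carbon bound to an amide-type nitrogen in a ring. The step from compound 1 to compound 2 is the only one that bears on this change, and it was modest. Since compound 3 keeps a saturated carbon substituent on this ring, though a larger one at a different position, a further shift of comparable or smaller size is expected. Compound 3 is therefore estimated at 2500 nM, with a range from 800 nM to 8000 nM, which means an expected step of a 1.5-fold lower number from compound 2 to compound 3 (0.18 log units; within the scatter).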

Compound 3, half-maximal inhibitory concentration: 8460 nM
Beside the measured number, compound 3's estimate is 3.4-fold (0.53 log units) below it, outside the stated range (above it).
By their numbers in this assay, from the lowest: compound 2; then compound 3; then compound 1.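

In this assay, 4-(tert-butyl)phenyl in place of 3-methylphenyl on a saturated chain carbon bound to an amide-type nitrogen in a ring does not carry the gain further, giving a 2.2-fold higher number from compound 2 to compound 3 (0.35 log units; beyond the scatter). The 4-(tert-butyl)benzyl group still gives a 2.4-fold lower number from compound 1 to compound 3 (0.37 log units; beyond the scatter), so among these three compounds both substituted benzyl groups give lower numbers than the plain benzyl group of compound 1, while the number does not fall further with the 10-carbon group. Nothing available explains this order.

The step from compound 2 to compound 3 changes both the group and its place on the aromatic ring, so the two contributions cannot be separated. Going by these compounds, whether a methoxy group, an amine or a carboxylic acid on this benzyl ring would also lower the number remains open.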